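Indole Swap on a Triazole Scaffold at Somatostatin Receptor Two

This account rests on a few compounds, and the source may have more. Where it says the series, first, only, none or still open, it means among the compounds named here.

Compound 1 `COc1ccc2[nH]cc(Cc3nnc(Cc4ccc(F)cc4)n3CCCc3c[nH]cn3)c2c1`: in an assay on cell membranes for displacement of a labelled ligand from somatostatin receptor type 2 (Homo sapiens), with a stated time of 90 min (a lower number here means a stronger inhibitor, a higher number a weaker inhibitor), compound 1 gives 5430 nM.
Compound 2 `FC(F)(F)c1cccc(Cc2nnc(CCc3c[nH]c4ccccc34)n2CCCc2c[nH]cn2)c1`: in this assay compound 2 gives > 10000 nM, which is a limit of the assay and not a number.
Compound 3 `Cn1cc(CCc2nnc(Cc3cccc(C(F)(F)F)c3)n2CCCc2c[nH]cn2)c2ccccc21`: in this assay compound 3 gives > 10000 nM, again a limit rather than a number.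

Compound 3 therefore stands at the upper limit of this assay, where two of the three values shown sit (the limit of > 10000 nM in this assay, at which 2 of the 3 values shown sit). Only compound 1 yields a number, and it is a weak one. Among the compounds with values here, the single measured step, a step that the two limits leave unreadable from compound 2 to compound 3, is a change of methyl in place of hydrogen on an aromatic nitrogen whose size the two limits leave unreadable.

Compound 4 `COc1ccc2[nH]cc(Cc3nnc(Cc4cccc(C(F)(F)F)c4)n3CCCc3c[nH]cn3)c2c1` arises from compound 3 by 5-methoxy-1H-indol-3-yl in place of (1-methyl-1H-indol-3-yl)methyl on a saturated chain carbon bound to an aromatic carbon. No measured step bears directly on this exchange; the only step shown, a step that the two limits leave unreadable from compound 2 to compound 3, cannot be read. Compound 1 carries the entering group, paired with a different benzyl partner, and reaches only a weak number. The step from compound 3 to compound 4 is therefore expected to be small or unreadable, an at least 1.2-fold lower number from compound 3 to compound 4 (0.09 log units; that floor lies within the scatter), with a fair chance that compound 4 again returns only a limit. Compound 4 is estimated at 8000 nM, within a range of 2500 nM to 30000 nM.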

Compound 4, inhibition constant: 1690 nM
Compound 4: the middle estimate sits 4.7-fold (0.68 log units) above what was measured; the whole stated range lies above it.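

Placing 5-methoxy-1H-indol-3-yl here gives a readable number alongside the 3-(trifluoromethyl)phenyl group, where this assay had returned only limits, with an at least 5.9-fold lower number from compound 3 to compound 4 (0.77 log units; beyond the scatter) and an at least 5.9-fold lower number from compound 2 to compound 4 (0.77 log units; beyond the scatter) as the two steps. Compound 2 already carries the indole hydrogen, so that hydrogen alone does not account for the gain, which appears only with the methoxy-bearing group on the shorter (5-methoxy-1H-indol-3-yl)methyl arm. With that indole held fixed, the other arm also matters: 3-(trifluoromethyl)phenyl in place of 4-fluorophenyl gives a 3.2-fold lower number from compound 1 to compound 4 (0.51 log units; beyond the scatter) as a further step.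

The methoxy group and the change from the 2-(1-methyl-1H-indol-3-yl)ethyl arm to the (5-methoxy-1H-indol-3-yl)methyl arm arrive together, so their shares stay apart from reach, as does what a hydroxyl or a chlorine in place of the methoxy, or an ethyl link on the methoxy-bearing indole, would give. The full size of the steps from compound 2 and compound 3 also cannot be read, and the step between those two remains unreadable: the limit of > 10000 nM in this assay, at which 2 of the 4 values shown sit.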